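Swapping methylamino for pyrrolidin-1-yl in a weak set

The source may hold more compounds than are shown below. What is called first, only, known or untested is meant among the compounds shown, and "the series" means these compounds.

Compound 1 `Brc1cccc(Nc2nc(/C=C/c3ccccc3)nc3ccsc23)c1`: > 1000000 nM
Compound 2 `CNc1nc(/C=C/c2ccco2)nc2ccsc12`: 811000 nM
Compound 3 `CNc1nc(/C=C/c2cc(OC)c(OC)c(OC)c2)nc2ccsc12`: > 1000000 nM

These three compounds were tested in a functional assay on L02 cells (Homo sapiens) for inhibition, read by Griess assay, with stated times of 1 h and 24 h; a higher number here means a weaker inhibitor, a lower number a stronger inhibitor. Compound 1 gives > 1000000 nM, which is a limit of the assay and not a number. Compound 3 gives > 1000000 nM, which is also a limit and not a number. Compound 3 thus sits at the limit of > 1000000 nM in this assay, at which 2 of the 3 values shown sit. Only compound 2 returns an actual number, 811000 nM. No two of these compounds differ in just one place, so the data show no direct measure of what a single change does.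

The next compound is compound 4 `COc1cc(/C=C/c2nc(N3CCCC3)c3sccc3n2)cc(OC)c1OC`. It differs from compound 3 in one place: pyrrolidin-1-yl in place of methylamino on an aromatic carbon. Pyrrolidin-1-yl stands in place of methylamino on an aromatic carbon, and the rest of the structure stays the same. Among the measured compounds shown here, with no measured step as a guide, no change beyond the usual scatter is expected in this assay, in either direction. Compound 4 may well return only a limit too. The expected value for compound 4 is 1000000 nM, with an estimated range of 400000 nM to 2500000 nM. This estimate amounts to an expected a number no higher from compound 3 to compound 4 (the limit leaves the size open).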

Compound 4, half-maximal inhibitory concentration: 681000 nM
Beside the measured number, compound 4's estimate is 1.5-fold (0.17 log units) above it, and the stated range covers the measured number.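

In this assay, replacing methylamino with pyrrolidin-1-yl, on the aromatic carbon next to the ring nitrogen, gives the first direct measure of a single change in this set: an at least 1.4-fold lower number from compound 3 to compound 4 (0.16 log units; that floor lies within the scatter). From the compounds shown here alone, compound 3 carries only a limit, so the true size of this step stays unknown, and its floor alone does not establish a real gain. What the pair does show is that this place accepts a ring in place of the small methylamino group, and loses the hydrogen-bond donor, with compound 4 still returning an actual number rather than a limit.

The compounds shown leave open whether the lost donor or the added ring matters more, a question that dimethylamino, which has no such donor and no ring, or a six-membered morpholin-4-yl group at the same place could help to separate. Any reading of this set also remains restricted by how many of its values are not numbers: the limit of > 1000000 nM in this assay, at which 2 of the 4 values shown sit.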